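Swapping chloro for methylsulfanyl in an antiproliferative pair

A few compounds are considered here, and "the series" means these few. Any claim that something is new, unique, unknown or untested is made for them only; others in the source may bear on it.

Compound 1 `O=C(CCc1cccc2c1B(O)OC2)Nc1cccc(-c2ccc(F)cc2)c1`: 93 nM
Compound 2 `O=C(CCc1cccc2c1B(O)OC2)Nc1cccc(-c2cccc(Cl)c2)c1`: 300 nM

Both compounds were tested in a functional assay on SK-OV-3 cells (Homo sapiens) for antiproliferative activity, read by MTT assay, with a stated time of 72 h; a lower number here means a stronger inhibitor, a higher number a weaker inhibitor. Compound 2, at 300 nM, has the higher of the two numbers and is the weaker inhibitor, and its gap to compound 1 lies beyond the usual scatter.

The next compound, compound 3 `CSc1cccc(-c2cccc(NC(=O)CCc3cccc4c3B(O)OC4)c2)c1`, has not yet been measured. It differs from compound 2 by methylsulfanyl in place of chloro on an aromatic carbon, meta to a large group (methylsulfanyl in place of chloro on an aromatic carbon).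

Going by the values given here, only one measured step bears on this change: a 3.2-fold higher number from compound 1 to compound 2 (0.51 log units; beyond the scatter). That step was modest, and it exchanged 4-fluorophenyl for 3-chlorophenyl, so it shows that a change in this part of the structure can move the number. Among the compounds with values here, it does not give a direction for the new change, and no measured compound carries methylsulfanyl. A step of about that size at most is therefore expected, with no firm direction, and the expected step is a 1.1-fold lower number from compound 2 to compound 3 (0.03 log units; within the scatter). Compound 3 is estimated at 280 nM, with an expected range of 100 nM to 800 nM.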

Compound 3, half-maximal inhibitory concentration: 150 nM
Compound 3: the middle estimate sits 1.9-fold (0.27 log units) above what was measured; the measured number falls inside the stated range.
By their numbers in this assay, from the lowest: compounds 1, 3 and 2 (each within the scatter of the next, the first and the last beyond it).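

In this assay, exchanging chloro for methylsulfanyl on an aromatic carbon, meta to a large group, gave a 2.0-fold lower number from compound 2 to compound 3 (0.30 log units; within the scatter) and so replaced 1 heavy atom with 2 without a shift that can be told apart from the scatter. The wider comparison with the 4-fluorophenyl compound gave a 1.6-fold higher number from compound 1 to compound 3 (0.21 log units; within the scatter) and places compound 3 within the scatter of both earlier compounds, although those two stand apart beyond it; the earlier step had shown only that this part of the structure can move the number, whereas this pair shows that a sulfur-bearing group can be carried here with no separation from either neighbour. No measurement at hand accounts for this outcome.

The compounds shown leave open whether an amine, a carboxylic acid or a longer chain such as ethylsulfanyl on this same aromatic carbon would also stay within the scatter of compound 3. They also leave open whether the closeness of compound 2 and compound 3 extends beyond this single cell assay.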